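Compound 1 as the Anchor for an Amine Swap

The source may hold more compounds than are shown below. What is called first, only, known or untested is meant among the compounds shown, and "the series" means these compounds.

- Compound 1 `CC(=O)NCC(=O)N1CCc2c(C)c3c(n2-c2ccc(C(N)=O)c(c2)N[C@@H](C)CC1)CC(C)(C)CC3=O` gives 1550 nM as a measured number
- Compound 2 `Cc1c2c(n3c1CCCN(CCN)C(=O)[C@H](C)Nc1cc-3ccc1C(N)=O)CC(C)(C)CC2=O` gives > 20000 nM as a limit of the assay

Among the compounds with values here, in a functional assay on HCT-116 cells (Homo sapiens) for antiproliferative activity (a lower number here means that less compound is needed, a higher number that more compound is needed for the effect), compound 1 holds the only true number, at 1550 nM in this small set. Compound 2 reads > 20000 nM and that is a limit, not a number.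

Compound 3 `Cc1c2c(n3c1CCN(C(=O)[C@@H](C)N)CC[C@H](C)Nc1cc-3ccc1C(N)=O)CC(C)(C)CC2=O` keeps the core of compound 1 and changes at one place, on a carbonyl carbon whose other neighbours are amide-type nitrogen in a ring. There, 1-aminoethyl stands in place of acetamidomethyl 1-aminoethyl in place of acetamidomethyl on a carbonyl carbon and the rest stays the same. Within the data shown here, no measured pair shows what such a swap does in this assay so the expectation is loose. A modest move towards a higher number is expected, and it may not stand far beyond the scatter. The expected step of a 1.9-fold higher number from compound 1 to compound 3 (0.29 log units; within the scatter) is therefore small and uncertain. For compound 3 the estimated value is 3000 nM with an expected range from 700 nM to 14000 nM in this assay.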

Compound 3, half-maximal effective concentration in the HCT-116 assay: 710 nM
Compound 3: the middle estimate sits 4.2-fold (0.63 log units) above what was measured; measured number inside the range.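

Within the data shown here, this gives the first measured step at this position: in the HCT-116 assay, 1-aminoethyl in place of acetamidomethyl on a carbonyl carbon gives a 2.2-fold lower number from compound 1 to compound 3 (0.34 log units; beyond the scatter), so fewer heavy atoms here did not cost activity in these cells. Solubility moves with the same change in a physicochemical assay for solubility; a lower number here means a less soluble compound, a higher number a more soluble compound: the measured solubility of compound 1, 5 ug/mL, and of compound 3, > 100 ug/mL, an at least 20-fold higher number (1.30 log units; beyond the scatter). In the physicochemical assay compound 1 gives 5 ug/mL. As far as these compounds go, in the physicochemical assay compound 3 gives > 100 ug/mL, which is a limit of the assay and not a number, so the full size of that step stays unknown.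

Still open, from the compounds shown here alone, is how a simple aminomethyl group, a longer aminoalkyl chain or a carboxylic acid would read on the same carbonyl carbon. Also open is whether the defined stereocentre of 1-aminoethyl matters, since the mirror-image group is not among the compounds shown.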